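Chloro for fluoro on the imine-bearing phenyl ring

A few compounds are considered here, and "the series" means these few. Any claim that something is new, unique, unknown or untested is made for them only; others in the source may bear on it.

Compound 1 `C[C@H](c1ccc(C(=O)NCCC(=O)O)cc1)N1C(=O)C(c2ccc(F)cc2)=N[C@]12CC[C@@H](C(C)(C)C)CC2` gives 430 nM in a functional assay on CHO cells for antagonist activity at Glucagon receptor (Homo sapiens), read by cAMP accumulation, with stated times of 30 min and 45 min; on this read-out higher numbers stand for weaker inhibition and lower numbers for stronger inhibition. Compound 2 `C[C@H](c1ccc(C(=O)NCCC(=O)O)cc1)N1C(=O)C(c2cccc(F)c2)=N[C@]12CC[C@@H](C(C)(C)C)CC2` gives 560 nM in this assay. Among the compounds with values here, the one step measured so far, a 1.3-fold higher number from compound 1 to compound 2 (0.11 log units; within the scatter), moves the fluorine around the ring and stays within the scatter, so compound 2 sits at a number indistinguishable from that of compound 1. Compound 3 `C[C@H](c1ccc(C(=O)NCCC(=O)O)cc1)N1C(=O)C(c2cccc(Cl)c2)=N[C@]12CC[C@@H](C(C)(C)C)CC2` is the next point: the change from compound 2 is chloro in place of fluoro on an aromatic carbon. Within the data shown here, no measured step exchanges one halogen for another, so nothing speaks directly to this change; the only step on hand, a 1.3-fold higher number from compound 1 to compound 2 (0.11 log units; within the scatter), shows that the fluorine on this ring is tolerant of repositioning. On that basis the expected step is a 1.1-fold lower number from compound 2 to compound 3 (0.05 log units; within the scatter), nothing beyond the scatter in this assay. Compound 3 is therefore estimated at 500 nM in this assay, with a range from 200 nM to 1300 nM.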

Compound 3, half-maximal inhibitory concentration: 480 nM
For compound 3 the middle estimate is 1.0-fold (0.02 log units) above the measured one; the measured number falls inside the stated range.
By their numbers in this assay, from the lowest: compounds 1, 3 and 2 (each within the scatter of the next).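

In this assay, within the data shown here, chloro in place of fluoro on an aromatic carbon, meta to a large group, gives a 1.2-fold lower number from compound 2 to compound 3 (0.07 log units; within the scatter), so the first halogen exchange leaves no readable change at this position. The comparison with the 4-fluorophenyl compound, which changes both the halogen and its place on the ring, gives a 1.1-fold higher number from compound 1 to compound 3 (0.05 log units; within the scatter), so this double change also stays within the scatter. No supporting data are available to explain this result.

All three compounds carry a single halogen on this ring, so the compounds shown leave open how an amine, a hydroxyl or a carboxylic acid in this place would read in this assay. Also open, from the compounds shown here alone, is where the unsubstituted phenyl would stand relative to these halogenated rings.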